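Chlorophenyl Carbamoyl Group Enters on the Amide-Type Nitrogen

This account rests on a few compounds, and the source may have more. Where it says the series, first, only, none or still open, it means among the compounds named here.

Of the compounds shown here, three sharing one core have been measured in an ADME assay on L6 cells (Rattus norvegicus) for cytotoxicity, read by resazurin assay, with a stated time of 70 h; on this read-out lower numbers stand for stronger inhibition and higher numbers for weaker inhibition. Compound 1 (`COc1ccc(/C=C/C(=O)NCCCC(C)Nc2cc(OC)cc3cccnc23)cc1`) gives > 100 ug/mL, which is a limit of the assay and not a number. Compound 2 (`COc1cc(NC(C)CCCNC(=O)/C=C/c2ccc(Cl)cc2)c2ncccc2c1`) gives 7.1 ug/mL, and compound 3 (`COc1cc(NC(C)CCCNC(=O)Nc2cccc(F)c2)c2ncccc2c1`) gives 9.18 ug/mL. These two numbers lie within the scatter of each other, as a 1.3-fold higher number from compound 2 to compound 3 (0.11 log units; within the scatter) shows, so compound 3 stands level with compound 2. Both steps away from compound 1 are large: an at least 14-fold lower number from compound 1 to compound 2 (1.14 log units; beyond the scatter) and an at least 10-fold lower number from compound 1 to compound 3 (1.03 log units; beyond the scatter).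

Compound 4 (`COc1cc(NC(C)CCCNC(=O)NNC(=O)Nc2ccc(Cl)cc2)c2ncccc2c1`) has yet to be measured. It carries ((4-chlorophenyl)carbamoyl)amino in place of 3-fluorophenyl on an amide-type nitrogen. Going by the values given here, no measured step makes this exact change. The nearest guide is the swap at the carbonyl carbon, where a 1.3-fold higher number from compound 2 to compound 3 (0.11 log units; within the scatter) stayed within the scatter. Compound 4 also lacks the 2-(4-methoxyphenyl)ethenyl of compound 1, so an at least 10-fold lower number from compound 1 to compound 3 (1.03 log units; beyond the scatter) offers no reason to expect a return to the limit. The expected change is a 1.3-fold higher number from compound 3 to compound 4 (0.12 log units; within the scatter), which would not pass beyond the scatter in this assay. For compound 4 the estimated value is 12 ug/mL, with an expected range from 3.5 ug/mL to 50 ug/mL.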

Compound 4, half-maximal inhibitory concentration: 43.3 ug/mL
The estimate for compound 4 lay 3.6-fold (0.56 log units) below the measured number; the range from low to high includes it.
By their numbers in this assay, from the lowest: compounds 2 and 3 (each within the scatter of the next); then compound 4. At a limit, above all of these: compound 1.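

In this assay, the change at the amide-type nitrogen gives a 4.7-fold higher number from compound 3 to compound 4 (0.67 log units; beyond the scatter), while the swap at the carbonyl carbon gave a 1.3-fold higher number from compound 2 to compound 3 (0.11 log units; within the scatter). Going by these compounds alone, this is therefore the first step among the compounds with readable numbers to pass beyond the scatter, and it shows that inhibition in this assay responds to what is carried on this nitrogen. The step is modest, though, and compound 4 still gives a readable number, so this change does not take it to the limit that only compound 1 shows: the limit of > 100 ug/mL in this assay, at which 1 of the 4 values shown sits.

The change also has several parts: ((4-chlorophenyl)carbamoyl)amino brings in more heavy atoms, hydrogen-bond donors and an acceptor, and it carries chlorine where 3-fluorophenyl carried fluorine, so the compounds shown cannot separate the contribution of the added carbamoyl amino link from that of the halogen. Going by these compounds, it also stays open how a 4-chlorophenyl set directly on the amide-type nitrogen would read, or how a ring bearing an amine or a carboxylic acid would read at the same place.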